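Three Cores, One Number, and a Sulfur-Linked Nitrile

This account rests on a few compounds, and the source may have more. Where it says the series, first, only, none or still open, it means among the compounds named here.

The series rests on three compounds that share a chlorinated fused core and a methyl-substituted aryl ring but differ in how that core is completed. Compound 1 `Cc1ccc(-c2nc(NO)c3cc(Cl)ccc3n2)cc1` carries a hydroxyamino group; compound 2 `Cc1ccc(-c2nc3ccc(Cl)cc3c(=O)n2N)cc1` carries an amino group on a ring nitrogen beside a carbonyl; compound 3 `Cc1ccc(-c2nc3ccc(Cl)cc3c(=S)o2)cc1` carries a thiocarbonyl. In a functional assay on HeLa cells (Homo sapiens) for antiproliferative activity, read by MTT assay, with a stated time of 48 h (a higher number here means a weaker inhibitor, a lower number a stronger inhibitor), compound 1 gives 12.7 ug/mL, compound 2 gives 12.1 ug/mL, and compound 3 gives 13.3 ug/mL. Compound 1 thus sits among three numbers that lie within the scatter of one another, with compound 3 nearest and compound 2 only a hair further away, so none of the three can be called stronger or weaker than the others.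

Compound 4 `Cc1ccc(-c2nc(SCC#N)c3cc(Cl)ccc3n2)cc1` is the next step from compound 1: (cyanomethyl)sulfanyl in place of hydroxyamino on an aromatic carbon. Going by the values given here, no measured pair in this set isolates such a change, and the three measured compounds, despite quite different completions of the core, all land at about the same value in this assay. The expectation for compound 4 is therefore a step from compound 1 to compound 4 of a 1.1-fold lower number from compound 1 to compound 4 (0.02 log units; within the scatter), essentially none beyond the scatter. Compound 4 is estimated at 12 ug/mL, with a plausible range from 5 ug/mL to 30 ug/mL.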

Compound 4, half-maximal inhibitory concentration: 3.76 ug/mL
Beside the measured number, compound 4's estimate is 3.2-fold (0.50 log units) above it; the measured number lies below the stated range.
By their numbers in this assay, from the lowest: compound 4; then compounds 2, 1 and 3 (each within the scatter of the next).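

In this assay, going by these compounds alone, the exchange of hydroxyamino for (cyanomethyl)sulfanyl gives a 3.4-fold lower number from compound 1 to compound 4 (0.53 log units; beyond the scatter) and so provides the first step in this set that isolates a change in one place; it is modest in size but lies beyond the scatter. It shows that the read-out responds to what stands on this aromatic carbon, next to the ring nitrogen of the six-membered aromatic ring with 2 nitrogen, and that the number goes down when a group with 0 hydrogen-bond donors replaces one with 2. Nothing available explains why the number moves in this direction.

The compounds shown leave open which part of the new group carries the step, since the sulfur link, the methylene and the nitrile all enter together, and a plain methylsulfanyl group or a thioether with a longer chain ending in a nitrile would be needed to pull these apart. They also leave open how an amine or a carboxylic acid on the same carbon would read in this assay.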